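The compounds below may be only part of what the source reports. "The series", "measured", "known", "first", "only" and "open" are said of these compounds alone.

In a functional assay on MCF7 cells (Homo sapiens) for cytotoxicity, read by MTT assay, with a stated time of 72 h (a higher number here means a weaker inhibitor, a lower number a stronger inhibitor), compound 1 `O=C(CCl)Nc1ccc(C(=O)/C=C/c2cccc(Cl)c2)cc1` gives 5340 nM and compound 2 `O=C(CSC(=S)N[C@H]1CCOC1=O)Nc1ccc(C(=O)/C=C/c2ccc(Br)cc2)cc1` gives 18700 nM as the higher of the two numbers. The gap between them lies beyond the scatter. Compound 3 `O=C(CSC(=S)N[C@H]1CCOC1=O)Nc1ccc(C(=O)/C=C/c2cccc(Cl)c2)cc1` keeps everything in compound 2 except one group: 3-chlorophenyl in place of 4-bromophenyl on a double-bonded chain carbon bound to a double-bonded chain carbon and so 3-chlorophenyl stands in place of 4-bromophenyl on a double-bonded chain carbon bound to a double-bonded chain carbon.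

Within the data shown here, no step between measured compounds that differ in one place is available, so the size of this step is not anchored by any direct comparison. Compound 1 also carries 3-chlorophenyl and gives 5340 nM as only a weak pointer toward a lower number. The estimated change in this assay is a 1.4-fold lower number from compound 2 to compound 3 (0.16 log units; within the scatter) and is expected to stay small and within the scatter. For compound 3 the expected value is 13000 nM with an estimated range from 5500 nM to 30000 nM for repeated measurements.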

Compound 3, half-maximal inhibitory concentration: 11600 nM
For compound 3 the middle estimate is 1.1-fold (0.05 log units) above the measured one; the measured number falls inside the stated range.
By their numbers in this assay, from the lowest: compound 1; then compounds 3 and 2 (each within the scatter of the next).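

In this assay, 3-chlorophenyl in place of 4-bromophenyl on a double-bonded chain carbon bound to a double-bonded chain carbon gives a 1.6-fold lower number from compound 2 to compound 3 (0.21 log units; within the scatter) and so does not separate these two groups at this position. Among these compounds, with 3-chlorophenyl held fixed, the group of 10 heavy atoms in place of one chlorine atom, on a saturated chain carbon bound to a carbonyl carbon, gives a 2.2-fold higher number from compound 1 to compound 3 (0.34 log units; beyond the scatter) and is the only one of the two steps beyond the scatter. No measurement bearing on the cause of either step is available.

As far as these compounds go, this single aryl step alters the halogen and its ring numbering together, so the contribution of each stays open. Also open, from the compounds shown here alone, is how an amine in place of the chlorine atom on the saturated chain carbon, or unsubstituted phenyl on the double-bonded chain carbon, would read.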